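Solubility notes on a thienopyrimidine-free description: aryl substituent series

A few compounds are considered here, and "the series" means these few. Any claim that something is new, unique, unknown or untested is made for them only; others in the source may bear on it.

Compound 1 `CNc1nc(NCCCN(C)C)c2sc(-c3ccc(OC)nc3)cc2n1`: 25 ug/mL
Compound 2 `CNc1nc(NCCCN(C)C)c2sc(-c3ccc(N4CCNCC4)cc3)cc2n1`: 12.5 ug/mL

In a physicochemical assay for solubility, in phosphate buffer, at pH 6.5 (on this read-out higher numbers stand for higher solubility and lower numbers for lower solubility), compound 2 gives 12.5 ug/mL, and compound 1 gives 25 ug/mL; the two numbers lie within the usual scatter of each other, so no order between them is claimed. Compound 3 `CNc1nc(NCCCN(C)C)c2sc(-c3ccccc3)cc2n1` carries hydrogen in place of piperazin-1-yl on an aromatic carbon, hydrogen in place of piperazin-1-yl on an aromatic carbon. Within the data shown here, no step between measured compounds is available for this kind of change. The expectation for compound 3 is a drop in this assay beyond the scatter, roughly a 3.1-fold lower number from compound 2 to compound 3 (0.49 log units; beyond the scatter). Compound 3 is thus estimated at 4 ug/mL, within 1.2 ug/mL to 13 ug/mL.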

Compound 3, solubility: > 100 ug/mL
Compound 3 gave a limit, no number; the forecaster's own chance of this, stated with the estimate: 15%; at least 25-fold (1.39 log units) between middle value and limit.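

In this assay compound 3, with hydrogen in place of piperazin-1-yl on an aromatic carbon, gives > 100 ug/mL as a limit of the assay and not a number. Compounds 1 and 2 alone showed no separation, whereas the bare phenyl now gives an at least 8.0-fold higher number from compound 2 to compound 3 (0.90 log units; beyond the scatter) and also an at least 4.0-fold higher number from compound 1 to compound 3 (0.60 log units; beyond the scatter) with both steps beyond the scatter. Going by these compounds, the full size of both steps stays unknown: the limit of > 100 ug/mL in this assay, at which 1 of the 3 values shown sits.

Open, on these data alone, is how a small amine such as dimethylamino, a carboxylic acid or a longer chain at this place would read in this assay and whether any substituent there can match the bare phenyl.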